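Methoxy for propyl on the shared core

The source may report more compounds than this note shows. Statements on the series, on what has been measured and on what is new or still open speak of the compounds shown alone.

Measured so far in a functional assay (spleen, spleen) for activation, with Mus musculus as the target; a higher number here means that more compound is needed for the effect, a lower number that less compound is needed:
compound 1 `Cc1nc(N)c2nc(O)n(Cc3ccccc3)c2n1` — 1 uM
compound 2 `CCSc1nc(N)c2nc(O)n(Cc3ccccc3)c2n1` — 0.1 uM
compound 3 `CCCc1nc(N)c2nc(O)n(Cc3ccccc3)c2n1` — 1 uM

Compound 3 stands level with compound 1 at the digits shown, the two together at the high end of the three numbers; the one clearly lower number belongs to compound 2, and a 10-fold higher number from compound 2 to compound 3 (1.00 log units; beyond the scatter) marks that gap as beyond the scatter. Compound 4 `COc1nc(N)c2nc(O)n(Cc3ccccc3)c2n1` is the next member, differing from compound 3 in one place: methoxy in place of propyl on an aromatic carbon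

Among the measured compounds shown here, two measured steps bear on this change. Lengthening the chain gave nothing, as no change at the digits printed from compound 1 to compound 3 (within the scatter) shows; swapping the chain for a sulfur-linked group gave a clear drop, as a 10-fold lower number from compound 1 to compound 2 (1.00 log units; beyond the scatter) shows. The methoxy group of compound 4 is, like ethylsulfanyl, linked through a heteroatom but is shorter, so the outcome is expected to fall somewhere between the chain compounds and compound 2, most likely a small improvement that may not clear the scatter. The estimate for compound 4 in this assay is therefore 0.5 uM, with a range of 0.1 uM to 2 uM. That estimate corresponds to an expected step of a 2.0-fold lower number from compound 3 to compound 4 (0.30 log units; within the scatter).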

Compound 4, minimum effective concentration: 0.1 uM
Beside the measured number, compound 4's estimate is 5.0-fold (0.70 log units) above it; the range from low to high includes it.
By their numbers in this assay, from the lowest: compounds 2 and 4 (each within the scatter of the next); then compounds 1 and 3 (each within the scatter of the next).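

In this assay, the gain seen earlier with ethylsulfanyl on this aromatic carbon between two ring nitrogen atoms is no longer a single case: there is a 10-fold lower number from compound 3 to compound 4 (1.00 log units; beyond the scatter) and likewise a 10-fold lower number from compound 1 to compound 4 (1.00 log units; beyond the scatter) with methoxy on the same carbon. The two heteroatom-linked groups do not separate, with no change at the digits printed from compound 2 to compound 4 (within the scatter) on exchanging ethylsulfanyl for methoxy, so neither the change from sulfur to oxygen nor the difference between these two groups registers in this read-out. Across the four compounds the split therefore follows the linking atom, with oxygen and sulfur links giving the lower numbers and the carbon-linked methyl and propyl the higher ones, and no compound here goes against this.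

The data on hand give no explanation for this split. Still open, on these data alone, is whether it extends to other linking atoms and to larger groups, which an amine such as methylamino or a longer ether such as butoxy on this carbon would test, and whether a gain beyond the level of compounds 2 and 4 is available at this position at all.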